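The compounds below may be only part of what the source reports. "The series", "measured", "known", "first", "only" and "open" are said of these compounds alone.

Compound 1, `CC(C)(C)OC(=O)/C=C1/C(=O)Nc2ccccc21`, is the parent of this small set, carrying only the shared core with a tert-butyl ester on its exocyclic double bond. In a functional assay on HL-60 cells (Homo sapiens) for cytotoxicity, read by CCK-8 assay, with a stated time of 72 h (on this read-out higher numbers stand for weaker inhibition and lower numbers for stronger inhibition), compound 1 gives 2450 nM, the lowest of the three numbers recorded. Compound 2, `Cc1ccc2c(c1)/C(=C\C(=O)OC(C)(C)C)C(=O)N2`, returns 5000 nM in this assay, and compound 3, `CC(C)c1ccc2c(c1)/C(=C\C(=O)OC(C)(C)C)C(=O)N2`, returns 5290 nM. Both measured steps from the parent go the same way: a 2.0-fold higher number from compound 1 to compound 2 (0.31 log units; beyond the scatter) and a 2.2-fold higher number from compound 1 to compound 3 (0.33 log units; beyond the scatter). Between the two substituted analogues the difference is slight, a 1.1-fold higher number from compound 2 to compound 3 (0.02 log units; within the scatter).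

Compound 4, `COc1cccc2c1NC(=O)/C2=C/C(=O)OC(C)(C)C`, takes the parent in a different direction: methoxy in place of hydrogen on an aromatic carbon. Within the data shown here, no measured pair in the set has a methoxy group, and no measured substituent sits ortho to a fused ring, so the two alkyl steps are only a partial guide. What they do show is that each substituent placed on the aromatic ring of compound 1 raised the number in this assay by a modest amount, as seen in a 2.0-fold higher number from compound 1 to compound 2 (0.31 log units; beyond the scatter) and a 2.2-fold higher number from compound 1 to compound 3 (0.33 log units; beyond the scatter). Compound 4 is therefore expected to give a somewhat higher number than compound 1, a step of about a 1.6-fold higher number from compound 1 to compound 4 (0.21 log units; within the scatter) in this assay. The estimate for compound 4 in this assay is 4000 nM, with a range from 1800 nM to 9000 nM.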

Compound 4, half-maximal inhibitory concentration: 9680 nM
Beside the measured number, compound 4's estimate is 2.4-fold (0.38 log units) below it; measured number outside the range, above it.
By their numbers in this assay, from the lowest: compound 1; then compounds 2, 3 and 4 (each within the scatter of the next).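

In this assay, among these compounds, methoxy in place of hydrogen on an aromatic carbon, ortho to a fused ring and meta to a fused ring, gives a 4.0-fold higher number from compound 1 to compound 4 (0.60 log units; beyond the scatter), so a substituent at this position also moves the number up from the parent, and the first group here that carries a hydrogen-bond acceptor does not reverse the direction seen with the alkyl groups. Together with a 2.0-fold higher number from compound 1 to compound 2 (0.31 log units; beyond the scatter) and a 2.2-fold higher number from compound 1 to compound 3 (0.33 log units; beyond the scatter), this makes three ring substituents that all go the same way, none goes against that pattern, and the unsubstituted compound 1 keeps the lowest number of the set. Among the compounds shown here, nothing available explains this step, and with methoxy as the only group at this position, the effect of the group cannot be told apart from the effect of its place.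

As far as these compounds go, whether a methyl, a fluorine or an amine on this same carbon would raise the number as methoxy does remains open, as does whether methoxy would do so elsewhere on the ring. Also open, from the compounds shown here alone, is how these ring changes would read with a carboxylic acid or a methyl ester in place of the tert-butyl ester.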